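A few compounds are considered here, and "the series" means these few. Any claim that something is new, unique, unknown or untested is made for them only; others in the source may bear on it.

Of the compounds shown here, three sharing one core have been measured in a functional assay on CAKI-1 cells (Homo sapiens) for inhibition, read by sulforhodamine B assay, with a stated time of 48 h; a higher number here means a weaker inhibitor of growth, a lower number a stronger inhibitor of growth. Compound 1 `O=C(Nc1cccc(-n2cc(-c3ccncc3)c(-c3ccc(Cl)c(O)c3)n2)c1)Nc1cccc(C(F)(F)F)c1` gives 1750 nM, compound 2 `COc1cc(-c2nn(-c3cccc(NC(=O)Nc4cc(C(F)(F)F)cc(C(F)(F)F)c4)c3)cc2-c2ccncc2)ccc1Cl` gives 993 nM, and compound 3 `COc1cc(-c2nn(-c3cccc(NC(=O)c4cccc(C(F)(F)F)c4)c3)cc2-c2ccncc2)ccc1Cl` gives 2010 nM. Compound 3 stands at the highest of the three numbers; its gap to compound 1 lies within the scatter, while compound 2 sits one step lower, beyond the scatter. Compound 4 `COc1cc(-c2nn(-c3cccc(NC(=O)Nc4ccc(Cl)c(Cl)c4)c3)cc2-c2ccncc2)ccc1Cl` differs from compound 3 in a single place: (3,4-dichlorophenyl)amino in place of 3-(trifluoromethyl)phenyl on a carbonyl carbon. This brings compound 4 closer in kind to compound 1 and compound 2, which also carry a carbamoyl-type link, than to the carbonyl link of compound 3. Because compound 2 gives 993 nM with such a link, a modest move toward a lower number is expected, and the expected step is a 1.8-fold lower number from compound 3 to compound 4 (0.26 log units; within the scatter). Compound 4 is therefore estimated at 1100 nM, with a likely range from 450 nM to 2700 nM.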

Compound 4, concentration for 50% growth inhibition: 1120 nM
Compound 4: the middle estimate sits 1.0-fold (0.01 log units) below what was measured; the range from low to high includes it.
By their numbers in this assay, from the lowest: compounds 2, 4, 1 and 3 (each within the scatter of the next, the first and the last beyond it).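

On the carbonyl carbon, trading 3-(trifluoromethyl)phenyl for (3,4-dichlorophenyl)amino gives, in this assay, a 1.8-fold lower number from compound 3 to compound 4 (0.25 log units; within the scatter). This position therefore accepts a different aryl group, together with an added hydrogen-bond donor, without a readable shift in the number. Nothing on hand explains this outcome.

The step alters the ring substituents and the link to the ring together, so the share of each remains unresolved. Also open, on these data alone, is how a methylamino group or a longer alkyl chain would read at this carbon.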